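A Thiophene Ester Weighed Against Its Tolyl Parent

The source may hold more compounds than are shown below. What is called first, only, known or untested is meant among the compounds shown, and "the series" means these compounds.

Compound 2 `Cc1ccc(C(=O)OC2CCC(CN3CCN(c4cc(=O)c5cc(C(F)(F)F)cc([N+](=O)[O-])c5s4)CC3)CC2)cc1` stands at the bottom of the three numbers available in an ADME assay on cells (Hepatocyte, Mus musculus) for metabolic stability, with a stated time of 30 min (on this read-out higher numbers stand for a more stable compound and lower numbers for a less stable compound), giving 18%. Compound 1 `O=c1cc(N2CCN(CC3CCCCC3)CC2)sc2c(NO)cc(C(F)(F)F)cc12` gives 47.8% in this assay, and compound 3 `CC(=O)NC1CCC(CN2CCN(c3cc(=O)c4cc(C(F)(F)F)cc([N+](=O)[O-])c4s3)CC2)CC1` gives 94.9% in this assay. Among the compounds with values here, the only measured step that touches the ester side of the molecule is a number 76.9 percentage points higher from compound 2 to compound 3 (beyond the scatter), which replaces the whole group, acetamido in place of ((4-methylphenyl)carbonyl)oxy on a saturated ring carbon.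

Compound 4 `O=C(OC1CCC(CN2CCN(c3cc(=O)c4cc(C(F)(F)F)cc([N+](=O)[O-])c4s3)CC2)CC1)c1cccs1` differs from compound 2 by thiophen-2-yl in place of 4-methylphenyl on a carbonyl carbon. Here the ester itself stays; only the aromatic part on the carbonyl carbon changes. Within the data shown here, no measured step bears directly on such a swap, and the large step from compound 2 to compound 3 concerns a different kind of change, so it offers little guidance. A small step, likely within the scatter, is therefore expected in this assay, with no direction favoured. The estimate for compound 4 is 24%, with a range from 10% to 45%, which would mean an expected step of a number 6 percentage points higher from compound 2 to compound 4 (within the scatter).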

Compound 4, percent of the compound remaining: 1.8%
Compound 4: middle estimate off by 22.2 percentage points, on the high side, and the stated range ends above it.
By their numbers in this assay, from the lowest: compound 4; then compound 2; then compound 1; then compound 3.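

Within the data shown here, with the ester held in place, the aromatic part on the carbonyl carbon still moves the number in this assay (a number 16.2 percentage points lower from compound 2 to compound 4 (beyond the scatter)), which the earlier compounds could not show. The ester compounds now both lie far under the acetamido compound, and the step for thiophen-2-yl is the wider of the two (a number 93.1 percentage points lower from compound 3 to compound 4 (beyond the scatter)). Nothing available explains either step.

With only two aromatic esters shown, it remains open whether the shift belongs to the thiophene ring itself or to the loss of 4-methylphenyl, and an unsubstituted phenyl or a furan-2-yl on the same carbonyl carbon would help to separate the two. Going by these compounds, it is also open how far the low numbers follow the ester link, which a matching amine or ether on the saturated ring carbon would test.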